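Two Measured Amides and One Expected Value

This account rests on a few compounds, and the source may have more. Where it says the series, first, only, none or still open, it means among the compounds named here.

Measured compounds:
compound 1 `O=C(NCc1ccc(S(=O)(=O)c2ccccc2)cc1)c1cc2ncccc2s1`: 400 nM
compound 2 `O=C(NCc1ccc(S(=O)(=O)N2CCCCC2)cc1)c1cc2cnccc2o1`: 140 nM

In an assay for inhibition of Nicotinamide phosphoribosyltransferase (Homo sapiens), read by mass spectrometry, with stated times of 15 min and 30 min (a lower number here means a stronger inhibitor, a higher number a weaker inhibitor), compound 1 gives 400 nM, and compound 2 gives 140 nM. Compound 2 has the lower of the two numbers, and its gap to compound 1 lies beyond the usual scatter, so on these two numbers compound 2 is the stronger inhibitor.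

Compound 3 `O=C(NCc1ccc(S(=O)(=O)N2CCCCC2)cc1)c1ccn2ccnc2c1` is not yet measured. It keeps everything else of compound 2 and differs only in the group attached to the amide carbonyl: a group of 9 heavy atoms (7 carbon, 2 nitrogen; one five-membered aromatic ring with 2 hetero atoms, one six-membered aromatic ring with 1 hetero atom) in place of a group of 9 heavy atoms (7 carbon, 1 nitrogen, 1 oxygen; one five-membered aromatic ring with 1 hetero atom, one six-membered aromatic ring with 1 hetero atom), on a carbonyl carbon. Within the data shown here, no pair of measured compounds shows a step of this kind, so its size cannot be read from earlier data. Both groups are two fused aromatic rings of the same size, so no step beyond the scatter in this assay is expected in either direction, although a somewhat weaker result is possible.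

Compound 3 is therefore expected to give 250 nM in this assay, within a range of 60 nM to 1000 nM, which means an expected step of a 1.8-fold higher number from compound 2 to compound 3 (0.25 log units; within the scatter).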

Compound 3, half-maximal inhibitory concentration: 1800 nM
Beside the measured number, compound 3's estimate is 7.2-fold (0.86 log units) below it; the measured number lies above the stated range.
By their numbers in this assay, from the lowest: compound 2; then compound 1; then compound 3.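

In this assay, the group on the carbonyl carbon proves far more sensitive than its counted features suggest: exchanging one pair of fused aromatic rings for another with the same ring sizes and heavy-atom count gives a 13-fold higher number from compound 2 to compound 3 (1.11 log units; beyond the scatter). The two groups differ in that a nitrogen takes the place of the oxygen and the five-membered ring carries 2 hetero atoms rather than 1, so close likeness on paper does not make them interchangeable at this place. Nothing measured here accounts for this large step.

As far as these compounds go, whether the step follows from the change of hetero atom or from the different arrangement of the fused rings remains open. Also open, from the compounds shown here alone, is how a single phenyl ring on the same carbonyl carbon would compare with these fused groups.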